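Swapping the aryl group on the sulfonyl of a piperazine series

The compounds below may be only part of what the source reports. "The series", "measured", "known", "first", "only" and "open" are said of these compounds alone.

Measured compounds:
- compound 1 `COc1cc2nc(N3CCN(S(=O)(=O)c4ccccc4[N+](=O)[O-])CC3)nc(N)c2cc1OC`: 35000 nM
- compound 2 `COc1cc2nc(N3CCN(S(=O)(=O)c4ccc(C(C)(C)C)cc4)CC3)nc(N)c2cc1OC`: 4100 nM

In a functional assay on PC-3 cells (Homo sapiens) for inhibition (a higher number here means a weaker inhibitor, a lower number a stronger inhibitor), compound 2 gives 4100 nM, the lower of the two numbers recorded; compound 1 gives 35000 nM. For the measured compounds named here, the one measured step, an 8.5-fold lower number from compound 1 to compound 2 (0.93 log units; beyond the scatter), shows that the aryl group on the sulfonyl sulfur matters for this read-out. Compound 3 `COc1cc2nc(N3CCN(S(=O)(=O)c4cc(Cl)ccc4Cl)CC3)nc(N)c2cc1OC` carries a different aryl group at that same place: 2,5-dichlorophenyl in place of 4-(tert-butyl)phenyl on a sulfonyl sulfur. Going by the values given here, no measured step involves a dichlorinated ring, so the only guide is that leaving the 4-(tert-butyl)phenyl of compound 2 was, in the one case seen, associated with a sizeable change in this assay. The expectation is therefore a somewhat higher number for compound 3 than for compound 2, estimated as a 2.4-fold higher number from compound 2 to compound 3 (0.39 log units; beyond the scatter), while staying short of compound 1. Compound 3 is expected to give about 10000 nM in this assay, with a likely range from 3000 nM to 35000 nM.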

Compound 3, half-maximal inhibitory concentration: 60000 nM
The estimate for compound 3 lay 6.0-fold (0.78 log units) below the measured number; the measured number lies above the stated range.
By their numbers in this assay, from the lowest: compound 2; then compounds 1 and 3 (each within the scatter of the next).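

Moving from 4-(tert-butyl)phenyl to 2,5-dichlorophenyl on the sulfonyl sulfur gives in this assay a 15-fold higher number from compound 2 to compound 3 (1.17 log units; beyond the scatter) and so costs far more than the earlier comparison alone could suggest. Replacing 2-nitrophenyl with 2,5-dichlorophenyl gives a 1.7-fold higher number from compound 1 to compound 3 (0.23 log units; within the scatter) and leaves these two groups indistinguishable in this read-out, so compound 2, with the lowest number, stands apart from both of the others. Nothing available here explains why the 4-(tert-butyl)phenyl compound stands apart.

For the compounds shown here, with only one compound carrying a tert-butyl group, it remains open whether that group itself accounts for the lower number or whether other aryl groups would do the same. Also open, from the compounds shown here alone, is how a plain phenyl ring, or an aryl ring bearing an amine or a carboxylic acid, would behave in this assay at this sulfonyl sulfur.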